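Cyclobutyloxy benzofuran acids: removing the chloro substituent

The source may report more compounds than this note shows. Statements on the series, on what has been measured and on what is new or still open speak of the compounds shown alone.

Compound 3 `O=C(O)CCc1cc2cc(-c3cc(Cl)cc(OC4CCC4)c3)ccc2o1` carries a chloro on the same ring as the cyclobutyloxy group. In a functional assay on isolated protein for agonist activity at Free fatty acid receptor 1 (Homo sapiens), read by HTRF and inositol phosphate accumulation, with a stated time of 60 min (on this read-out lower numbers stand for an effect already at smaller amounts and higher numbers for an effect only at larger amounts of compound), compound 3 gives only a limit, > 9950 nM, and no number. The related analogues give numbers: compound 1 `O=C(O)CCc1cc2cc(-c3cccc(OC(F)(F)F)c3)ccc2o1` gives 1390 nM and compound 2 `Cc1cc(OC2CCC2)cc(-c2ccc3oc(CCC(=O)O)cc3c2)c1` gives 2960 nM in this assay. Within the data shown here, the one measured step that bears on the chloro is an at least 3.3-fold higher number from compound 2 to compound 3 (0.52 log units; beyond the scatter); it is known only as a limit because compound 3 sits at the limit of > 9950 nM in this assay, at which 1 of the 3 values shown sits. Compound 3 therefore stands at the weak end of the three values shown.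

Compound 4 `O=C(O)CCc1cc2cc(-c3cccc(OC4CCC4)c3)ccc2o1` differs from compound 3 by hydrogen in place of chloro on an aromatic carbon. The step from compound 2 to compound 3 says that chloro on this ring costs potency relative to methyl, so taking the chloro away is expected to bring the number back down, by at least the size of that step. The expected step is an at least 3.3-fold lower number from compound 3 to compound 4 (0.52 log units; beyond the scatter) in this assay. Compound 4 is estimated at 3000 nM, within 1000 nM to 9000 nM.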

Compound 4, half-maximal effective concentration: 2500 nM
Estimate against measurement, compound 4: 1.2-fold (0.08 log units) above; the measured number falls inside the stated range.
By their numbers in this assay, from the lowest: compounds 1, 4 and 2 (each within the scatter of the next, the first and the last beyond it). At a limit, above all of these: compound 3.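

Hydrogen in place of chloro on this aromatic carbon, meta to a cyclobutyloxy group, turns a limit into a number in this assay, with an at least 3.9-fold lower number from compound 3 to compound 4 (0.59 log units; beyond the scatter). Hydrogen and methyl at this position are not told apart, with a 1.2-fold lower number from compound 2 to compound 4 (0.07 log units; within the scatter), so among the three groups compared here only chloro stands out, and the cost seen earlier belongs to chloro and not to the loss of methyl. Cyclobutyl in place of trifluoromethyl on the oxygen is also not resolved, with a 1.8-fold higher number from compound 1 to compound 4 (0.25 log units; within the scatter).

On these data alone, the size of the chloro cost remains a bound, and compound 3 stands at a limit: the limit of > 9950 nM in this assay, at which 1 of the 4 values shown sits. Whether fluoro, methoxy or an amine at this position would track hydrogen and methyl or track chloro stays open.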